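Compound 2 to compound 4: sulfonamide substituent change

The source may hold more compounds than are shown below. What is called first, only, known or untested is meant among the compounds shown, and "the series" means these compounds.

Measured in a functional assay on DU-145 cells (Homo sapiens) for antiproliferative activity, read by sulforhodamine B assay, with a stated time of 72 h; a lower number here means a stronger inhibitor, a higher number a weaker inhibitor:
- compound 1 `O=C1CS/C(=N/Nc2nncc3ccccc23)N1c1ccccc1`: 97 nM
- compound 2 `Cc1cc(C)nc(NS(=O)(=O)c2ccc(Nc3nncc4ccccc34)cc2)n1`: 7.8 nM
- compound 3 `S=C(NNc1nncc2ccccc12)Nc1ccccc1`: 45 nM

Compound 2 has the lowest number of the three, and its gaps to compound 3 and compound 1 both lie beyond the scatter. Still unmeasured is compound 4 `O=S(=O)(Nc1nccs1)c1ccc(Nc2nncc3ccccc23)cc1`, which differs from compound 2 by one change: 1,3-thiazol-2-yl in place of 4,6-dimethylpyrimidin-2-yl on a sulfonamide nitrogen. For the measured compounds named here, no measured pair shows this change, so its size is not known from the data. A modest rise in the number in this assay is expected, starting from compound 2 at 7.8 nM. The estimated change is a 1.8-fold higher number from compound 2 to compound 4 (0.25 log units; within the scatter). For compound 4 the expected value is 14 nM, with an estimated range of 4 nM to 50 nM.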

Compound 4, half-maximal inhibitory concentration: 24 nM
Beside the measured number, compound 4's estimate is 1.7-fold (0.23 log units) below it, and the stated range covers the measured number.
By their numbers in this assay, from the lowest: compound 2; then compounds 4 and 3 (each within the scatter of the next); then compound 1.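

In this assay the sulfonamide nitrogen proves sensitive to its substituent: 1,3-thiazol-2-yl in place of 4,6-dimethylpyrimidin-2-yl gives a 3.1-fold higher number from compound 2 to compound 4 (0.49 log units; beyond the scatter) and so moves the number beyond the scatter. The step replaces a six-membered aromatic ring with a five-membered one while the counts of hydrogen-bond donors and acceptors stay the same. No measurement available here accounts for the step. Still open, from the compounds shown here alone, is whether the ring identity or the methyl groups drive it, which a pyrimidin-2-yl lacking those methyl groups would test. A plain phenyl on the same nitrogen would show whether ring nitrogen is needed at all.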